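Swapping the pyridine arm of compound 1 for a pyrazole

The source may hold more compounds than are shown below. What is called first, only, known or untested is meant among the compounds shown, and "the series" means these compounds.

Of the compounds shown here, three sharing the same core have been measured in an assay on HEK293 cells for agonist activity at transient receptor potential cation channel subfamily M member 8 (Homo sapiens), read by fluorescence and calcium flux, with a stated time of 15 min; a higher number here means that more compound is needed for the effect, a lower number that less compound is needed. Compound 1, `CCN(Cc1cccnc1)C(=O)COc1ccc(C)cc1`, gives 15400 nM. Compound 2, `CCC(C)N(Cc1cccs1)C(=O)COc1ccc(C)cc1`, gives 2000 nM, and compound 3, `Cc1ccc(OCC(=O)N(Cc2cccs2)c2nccn2C)cc1`, gives 1790 nM. Compound 1 therefore stands highest of the three, needing the most compound for the effect, well beyond the scatter from either of the other two.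

For the measured compounds named here, the only single-point step among the measured compounds, a 1.1-fold lower number from compound 2 to compound 3 (0.05 log units; within the scatter), concerns the group on the amide-type nitrogen and stays within the scatter. It says nothing about the arm attached through the chain carbon, which is where compound 4, `CCN(Cc1cn[nH]c1)C(=O)COc1ccc(C)cc1`, differs from compound 1: 1H-pyrazol-4-yl in place of pyridin-3-yl on a saturated chain carbon bound to an amide-type nitrogen. Going by the values given here, no measured step bears on this change, so there is no basis for expecting a step beyond the scatter in this assay, in either direction.

Compound 4 is thus expected to land near compound 1, at roughly 15000 nM, within a range of 5000 nM to 45000 nM, which means an expected step of a 1.0-fold lower number from compound 1 to compound 4 (0.01 log units; within the scatter).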

Compound 4, half-maximal effective concentration: "active" (no number reported)
The entry for compound 4 holds no number, and the estimate cannot be compared.
By their numbers in this assay, from the lowest: compounds 3 and 2 (each within the scatter of the next); then compound 1.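

For the compounds shown here, compound 4 is reported only as active, without a number, so no step from compound 1 to compound 4 can be read. On these data alone, how far 1H-pyrazol-4-yl in place of pyridin-3-yl moves the number remains open. No further evidence bears on this result.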